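The source may report more compounds than this note shows. Statements on the series, on what has been measured and on what is new or still open speak of the compounds shown alone.

Compound 2 `OCc1ccc(Nc2ncc(Cc3c(F)cccc3F)o2)cc1` carries a hydroxymethyl group on its shared core. In an ADME assay on MT2 cells (Homo sapiens) for cytotoxicity, read by MTT assay (a lower number here means that less compound is tolerated, a higher number that more compound is tolerated), compound 2 gives > 100000 nM, and this is a limit of the assay, not a number. Compound 2 therefore sits at the limit of > 100000 nM in this assay, at which 1 of the 2 values shown sits. Its nearest measured neighbour is compound 1 `COCc1ccc(Nc2ncc(Cc3c(F)cccc3F)o2)cc1`, which differs only in a methyl in place of hydrogen on an oxygen on a saturated carbon; in this assay compound 1 gives 32000 nM. Among the compounds with values here, the single measured step, an at least 3.1-fold higher number from compound 1 to compound 2 (0.49 log units; beyond the scatter), is the only guide available. Compound 3 `Fc1cccc(F)c1Cc1cnc(Nc2ccc(COCc3ccco3)cc2)o1` differs from compound 2 by (furan-2-yl)methyl in place of hydrogen on an oxygen on a saturated carbon. This change again places a group on an oxygen on a saturated carbon, as in compound 1, so a move opposite to that measured step is expected, giving compound 3 a lower number that may fall back inside the measured range. Compound 3 is estimated at 30000 nM, between 10000 nM and 100000 nM, which would mean an at least 3.3-fold lower number from compound 2 to compound 3 (0.52 log units; beyond the scatter).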

Compound 3, half-maximal cytotoxic concentration: 31000 nM
Compound 3: middle estimate off by 1.0-fold (0.01 log units), on the low side; measured number inside the range.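

In this assay, a much larger group on the oxygen also gives a lower number than the free hydroxy group (an at least 3.2-fold lower number from compound 2 to compound 3 (0.50 log units; beyond the scatter)), so this drop is not confined to methyl. Methyl and (furan-2-yl)methyl on this oxygen cannot be told apart (a 1.0-fold lower number from compound 1 to compound 3 (0.01 log units; within the scatter)), and adding the furan-2-yl ring to the methyl group therefore brings no readable change in this assay. The step from compound 2 remains a minimum, as compound 2 gives only a limit of the assay, not a number: the limit of > 100000 nM in this assay, at which 1 of the 3 values shown sits.

As far as these compounds go, it remains open whether the free hydroxy group itself is what matters, which an amine or a carboxylic acid in its place could test. A plain longer chain on the oxygen could show whether the furan ring has any part in this result.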